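A few compounds are considered here, and "the series" means these few. Any claim that something is new, unique, unknown or untested is made for them only; others in the source may bear on it.

Of the compounds shown here, three built on one shared core have been measured in an ADME assay on A549 cells (Homo sapiens) for cytotoxicity, read by resazurin assay, with a stated time of 48 h; a higher number here means that more compound is tolerated, a lower number that less compound is tolerated. Compound 1 `CCCCCCCCC(C)Nc1ccc(NC(=O)c2cc(Cl)ccc2O)c(Cl)c1` gives 21900 nM. Compound 3 `CCCN(CCC)c1ccc(NC(=O)c2cc(Cl)ccc2O)c(Cl)c1` gives 10700 nM. Compound 2 `CC1(Nc2ccc(NC(=O)c3cc(Cl)ccc3O)c(Cl)c2)CCCC1` gives 157000 nM, the highest of the three numbers, so among the measured compounds compound 2 is the one tolerated at the highest concentration.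

For the measured compounds named here, the single step that can be traced exactly shows a 15-fold lower number from compound 2 to compound 3 (1.17 log units; beyond the scatter); the number for compound 1 also lies clearly under that of compound 2.

Compound 4 `O=C(Nc1ccc(NCc2ccc(Br)cc2)cc1Cl)c1cc(Cl)ccc1O` has not yet been measured. It differs from compound 2 in one place: 4-bromobenzyl in place of 1-methylcyclopentyl on a nitrogen on an aromatic ring. As in the step to compound 3, the group on the nitrogen on the aromatic ring is exchanged, and both other groups seen at that nitrogen came with lower numbers than compound 2. A lower number for compound 4 is therefore expected, likely of a size comparable to a 15-fold lower number from compound 2 to compound 3 (1.17 log units; beyond the scatter) or somewhat smaller.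

For compound 4 the expected value in this assay is 20000 nM, within a range from 6000 nM to 70000 nM. That corresponds to an estimated step of a 7.9-fold lower number from compound 2 to compound 4 (0.89 log units; beyond the scatter).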

Compound 4, half-maximal cytotoxic concentration: 40900 nM
The estimate for compound 4 lay 2.0-fold (0.31 log units) below the measured number; low and high end bracket the measured number.
By their numbers in this assay, from the lowest: compound 3; then compounds 1 and 4 (each within the scatter of the next); then compound 2.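

In this assay the group on this nitrogen again matters: a ring-bearing group also gives a lower number than 1-methylcyclopentyl, with a 3.8-fold lower number from compound 2 to compound 4 (0.58 log units; beyond the scatter) as the step. That drop is real but smaller than the one seen with dipropylamino, and a 3.8-fold higher number from compound 3 to compound 4 (0.58 log units; beyond the scatter) separates the two replacements. The position therefore does not simply switch between one high and one low level, since compound 4 settles between compound 3 and compound 2 and three groups at this nitrogen give three separate levels.

Nothing measured here explains why these groups differ. On these data alone, it also stays open how much of the change comes from the bromine rather than the benzyl group, and how a plain benzyl group or a benzyl group carrying a carboxylic acid would compare.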